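Swapping a Benzyl Group for a Benzodioxin on One Core

The source may report more compounds than this note shows. Statements on the series, on what has been measured and on what is new or still open speak of the compounds shown alone.

Three sulfonamides sharing one core have been tested in a functional assay on Capan-2 cells (Homo sapiens) for inhibition, read by MTT assay, with a stated time of 72 h; on this read-out lower numbers stand for stronger inhibition of growth and higher numbers for weaker inhibition of growth. Compound 1 `O=S(=O)(NCCCNCc1ccc(Cl)cc1)c1cc(C(F)(F)F)cc(C(F)(F)F)c1` gives 2700 nM. Compound 2 `COc1cccc(CNCCCNS(=O)(=O)c2cc(C(F)(F)F)cc(C(F)(F)F)c2)c1` gives 6400 nM, and compound 3 `O=S(=O)(NCCCNCc1ccc(C(F)(F)F)cc1)c1cc(C(F)(F)F)cc(C(F)(F)F)c1` gives 2000 nM, the lowest of the three numbers shown, though compound 3 and compound 1 lie within the scatter of each other. The measured steps read: a 1.4-fold lower number from compound 1 to compound 3 (0.13 log units; within the scatter); a 2.4-fold higher number from compound 1 to compound 2 (0.37 log units; beyond the scatter); a 3.2-fold lower number from compound 2 to compound 3 (0.51 log units; beyond the scatter). Compound 4 `O=S(=O)(NCCCNCC1COc2ccccc2O1)c1cc(C(F)(F)F)cc(C(F)(F)F)c1` introduces a new change: 2,3-dihydro-1,4-benzodioxin-2-yl in place of 4-(trifluoromethyl)phenyl on a saturated chain carbon bound to an amine nitrogen. Within the data shown here, no measured step covers this group. Among the measured compounds shown here, since compound 2, the one other compound whose group carries hydrogen-bond acceptors, gave 6400 nM, a modest rise is expected, a 2.0-fold higher number from compound 3 to compound 4 (0.30 log units; within the scatter). Compound 4 is therefore estimated at 4000 nM, with a range from 1500 nM to 11000 nM.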

Compound 4, concentration for 50% growth inhibition: 2500 nM
Compound 4: the middle estimate sits 1.6-fold (0.20 log units) above what was measured, and the stated range covers the measured number.
By their numbers in this assay, from the lowest: compounds 3, 4 and 1 (each within the scatter of the next); then compound 2.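

In this assay the 2,3-dihydro-1,4-benzodioxin-2-yl group stands level with 4-(trifluoromethyl)phenyl and 4-chlorophenyl at this place, with a 1.3-fold higher number from compound 3 to compound 4 (0.10 log units; within the scatter) and a 1.1-fold lower number from compound 1 to compound 4 (0.03 log units; within the scatter). Only 3-methoxyphenyl stays apart, with a 2.6-fold lower number from compound 2 to compound 4 (0.41 log units; beyond the scatter), so carrying hydrogen-bond acceptors does not by itself go with a higher number among these compounds. Nothing at hand tells why these groups read as they do. Still open, going by these compounds, is whether a pyridyl or a cyclohexyl group at this place would give a similar number.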